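The source may hold more compounds than are shown below. What is called first, only, known or untested is meant among the compounds shown, and "the series" means these compounds.

Of the compounds shown here, three have been tested in an assay on isolated protein for inhibition of Nitric oxide synthase, inducible (Homo sapiens), with a stated time of 30 min, tested at 1 mM; on this read-out lower numbers stand for less inhibition and higher numbers for more inhibition at the one concentration tested (going by the name of the read-out). Compound 1 `Nc1ccc(Cl)cc1C1=NN(C(=O)C2CC2)CC1` and compound 2 `Nc1ccc(Cl)cc1C1=NN(C(=O)c2ccccc2)CC1` share a core and differ at one point only, (phenyl in place of cyclopropyl on a carbonyl carbon). In this assay compound 1 gives 18.9%, and compound 2 gives 17%; the step of a number 1.9 percentage points lower from compound 1 to compound 2 (within the scatter) is within the scatter, so these two values show no real difference.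

Compound 3 `COc1cc(N)c(C2=NN(C(=O)C3CC3)CC2)c(OC)c1OC` carries the same cyclopropylcarbonyl group as compound 1 but on a different core; the difference between the two cores is not broken down here. In this assay compound 3 gives 30.1%, the highest of the three numbers, and its steps to compound 1 and to compound 2 are both beyond the scatter.

Compound 4 `COc1cc(N)c(C2=NN(C(=O)c3ccccc3)CC2)c(OC)c1OC` has not yet been measured. It differs from compound 3 by phenyl in place of cyclopropyl on a carbonyl carbon, which is the same change as that from compound 1 to compound 2, at the same place. Since that earlier change produced a step of a number 1.9 percentage points lower from compound 1 to compound 2 (within the scatter) that was within the scatter, the step from compound 3 to compound 4 is expected to be of similar size, estimated at a number 2.1 percentage points lower from compound 3 to compound 4 (within the scatter). On that basis compound 4 is expected to give about 28% in this assay, with the estimate lying between 18% and 38%.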

Compound 4, a percentage reported as inhibition, at one concentration (the size of the read-out at that concentration, not a potency): 8.14%
For compound 4 the middle estimate is 19.9 percentage points above the measured one, outside the stated range (below it).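

In this assay, the change from cyclopropyl to phenyl on the carbonyl carbon gives a step of a number 22 percentage points lower from compound 3 to compound 4 (beyond the scatter), and this step does not match the one seen on the other core: the same change on two cores in this assay, a number 1.9 percentage points lower (within the scatter) from compound 1 to compound 2 and a number 22 percentage points lower (beyond the scatter) from compound 3 to compound 4, 20.1 percentage points apart, beyond the scatter of two such steps The change therefore cannot be carried from one core to the other in this series with its size kept, and the small step on the core of compound 1 proved a poor guide to the step on the core of compound 3. Within the data shown here, this rests on only two matched pairs, each read at a single concentration, so it shows that the size of the step differs with the core but not why it differs, which part of the core goes with the difference, or whether potency would differ in the same way.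

The compounds shown carry only cyclopropyl or phenyl on this carbonyl carbon, so it remains open how the two cores would compare with an amine or a longer carbon chain in that place. Going by these compounds, it also remains open whether the two cores would again give steps of different size with such groups, or whether the gap is particular to the change from cyclopropyl to phenyl.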